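From Methoxyphenoxy to Fluorobenzyl: a Permeability Estimate

A few compounds are considered here, and "the series" means these few. Any claim that something is new, unique, unknown or untested is made for them only; others in the source may bear on it.

Compound 2 `COc1cccc(Oc2ccc3c(NCCCNCc4cccc(OC)c4O)ccnc3c2)c1` was measured in an ADME assay for permeability, using PAMPA, with a stated time of 30 min, at pH 7.4 (on this read-out higher numbers stand for higher permeability and lower numbers for lower permeability), where compound 2 gives 317 10^-6 cm/s. Compound 1 `COc1ccc(Oc2ccc3c(NCCCNCc4cccc(OC)c4O)ccnc3c2)cc1` differs from it only in the methoxyphenyl on the oxygen; in this assay compound 1 gives 317 10^-6 cm/s, and the step of no change at the digits printed from compound 1 to compound 2 (within the scatter) leaves the read-out where it was, so compound 2 stands level with compound 1 at the digits shown. Compound 3 `COc1cccc(CNCCCNc2ccnc3cc(Cc4ccc(F)cc4)ccc23)c1O` has not yet been measured. It differs from compound 2 by 4-fluorobenzyl in place of 3-methoxyphenoxy on an aromatic carbon. Among the compounds with values here, the one measured step, from compound 1 to compound 2, exchanged one methoxyphenyl for another and produced no change beyond the scatter; it bears only loosely on the present change, in which the whole 3-methoxyphenoxy leaves and a 4-fluorobenzyl enters on an aromatic carbon of the shared core. Both measured compounds sit at the same reading, and nothing in the data points to a direction. Compound 3 is therefore expected to stay within the scatter, a step of a 1.1-fold lower number from compound 2 to compound 3 (0.02 log units; within the scatter). The estimated value of compound 3 in this assay is 300 10^-6 cm/s, with a range from 150 10^-6 cm/s to 600 10^-6 cm/s.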

Compound 3, apparent permeability: 23 10^-6 cm/s
Beside the measured number, compound 3's estimate is 13-fold (1.12 log units) above it; the whole stated range lies above it.
By their numbers in this assay, from the lowest: compound 3; then compounds 1 and 2 (each within the scatter of the next).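

Within the data shown here, the earlier pair showed only that moving the methoxy group on the phenoxy ring left the read-out in place, which said nothing about the group as a whole. Replacing that whole group on the same aromatic carbon of the shared core is a different matter: in this assay it gives a 14-fold lower number from compound 2 to compound 3 (1.14 log units; beyond the scatter), and the same exchange starting from 4-methoxyphenoxy gives a 14-fold lower number from compound 1 to compound 3 (1.14 log units; beyond the scatter), so the read-out at this position does respond to what is attached there. The exchange alters several things at once, taking 2 hydrogen-bond acceptors down to 0, replacing the oxygen-bearing group with a fluorine-bearing one and going from 9 heavy atoms to 8, and nothing measured here ties the drop to any one of these differences.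

The compounds shown leave open which part of the exchange carries the drop: the oxygen attached to the core, the methoxy group, the methylene of the benzyl or the fluorine. A 4-fluorophenoxy or a 3-methoxybenzyl group on this carbon would separate these parts, and a plain benzyl group would show what the fluorine contributes.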